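Swapping trifluoromethyl for difluoromethoxy in two cores

This account rests on a few compounds, and the source may have more. Where it says the series, first, only, none or still open, it means among the compounds named here.

Of the compounds shown here, three that share a nitroimidazo-oxazine-like head have been tested in an ADME assay on microsomes from liver (Mus musculus, strain CD1) for metabolic stability, read by LC-MS, with a stated time of 1 h; on this read-out higher numbers stand for a more stable compound and lower numbers for a less stable compound. Compound 1 `O=[N+]([O-])c1cn2c(n1)OC[C@@H](OCc1ccc(-c3ccc(C(F)(F)F)cc3)cc1)C2` gives 85%. Compound 2 `O=[N+]([O-])c1cn2c(n1)OC[C@@H](OCc1ccc(-c3ccc(OC(F)F)cc3)cc1)C2` gives 77%. The two differ by one change: difluoromethoxy in place of trifluoromethyl on an aromatic carbon. That change made a step of a number 8 percentage points lower from compound 1 to compound 2 (within the scatter), so the two numbers cannot be told apart with confidence.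

Compound 3 `O=[N+]([O-])c1cn2c(n1)OC[C@@H](OCc1ccc(-c3ccc(Cl)c(C(F)(F)F)c3)cc1)C2` gives 96%, the highest of the three numbers, and its steps to compound 1 and to compound 2 lie beyond the usual scatter. How the core of compound 3 differs from the core of compound 1 is not broken down here.

Compound 4 `O=[N+]([O-])c1cn2c(n1)OC[C@@H](OCc1ccc(-c3ccc(Cl)c(OC(F)F)c3)cc1)C2` has not yet been tested. It relates to compound 3 as compound 2 relates to compound 1: difluoromethoxy in place of trifluoromethyl on an aromatic carbon. The surroundings are not identical, since in compound 2 the new group sits para to a large group, while in compound 4 it sits ortho to a chloro group and meta to a large group, so this is the same kind of change rather than the same one.

Going by the values given here, the only guide is the earlier pair, where the step from compound 1 to compound 2 stayed within the scatter. On that basis, compound 4 is expected to show a step of a number 8 percentage points lower from compound 3 to compound 4 (within the scatter) in this assay. Compound 4 is therefore estimated at 88%, with a range from 76% to 97%.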

Compound 4, percent of the compound remaining: 86%
The estimate for compound 4 lay 2 percentage points above the measured number; the range from low to high includes it.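

On the second core, the swap of trifluoromethyl for difluoromethoxy gave a step of a number 10 percentage points lower from compound 3 to compound 4 (within the scatter) in this assay. Set beside the first core, the change behaved about the same on both, even though its surroundings were not identical, with the new group ortho to a chloro group and meta to a large group in compound 4: the same change on two cores in this assay, a number 8 percentage points lower (within the scatter) from compound 1 to compound 2 and a number 10 percentage points lower (within the scatter) from compound 3 to compound 4, 2 percentage points apart, within the scatter of two such steps. This shows that, for these two pairs, carrying the change to another core gave a similar result, but it does not show a rule for the whole series, and since each step lies within the scatter, neither pair shows on its own that the swap has any real effect on the read-out.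

The compounds shown compare only these two groups, so it remains open how a nitrile, a methoxy group or an amine would fare on the same aromatic carbon. On these data alone, it also remains open whether the same swap would give a similar step on a core with a different group in place of the chloro group, or on a core with a longer chain in place of the large group.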